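From compound 3 to compound 4 in a cell toxicity test

The source may report more compounds than this note shows. Statements on the series, on what has been measured and on what is new or still open speak of the compounds shown alone.

Three related compounds have been tested in an ADME assay on L6 cells (Rattus norvegicus) for cytotoxicity, read by resazurin assay, with a stated time of 72 h; a higher number here means a weaker inhibitor, a lower number a stronger inhibitor. Compound 1 `OC(c1ccc(Cl)cc1)(c1cccnc1)c1ccccc1Br` gives 55200 nM and compound 3 `OC(c1cccnc1)(c1ccc(Cl)cc1F)c1ccc(Cl)cc1F` gives 56300 nM, two values within the usual scatter of each other. Compound 2 `N#Cc1cccc(C(O)(c2ccc(Cl)cc2)c2cccnc2)c1` gives only a limit, > 100000 nM.

Compound 4 `OC(c1cccnc1)(c1cccs1)c1ccc(Cl)cc1F` differs from compound 3 by carrying thiophen-2-yl in place of 4-chloro-2-fluorophenyl on a saturated chain carbon bound to two aromatic carbons and an oxygen on a saturated carbon. Among the compounds with values here, no measured pair of compounds shows what such a swap does. No step beyond the usual scatter is therefore expected in this assay, with an estimated 1.2-fold higher number from compound 3 to compound 4 (0.06 log units; within the scatter). For compound 4 the expected value is 65000 nM, with an estimated range of 30000 nM to 100000 nM.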

Compound 4, half-maximal inhibitory concentration: > 100000 nM
Compound 4: no number, only a limit; the forecaster's own chance of this, stated with the estimate: 25%; middle value at least 1.5-fold (0.18 log units) from the limit.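

With thiophen-2-yl in place of 4-chloro-2-fluorophenyl on this saturated chain carbon, this assay gives the only readable step among these compounds, an at least 1.7-fold higher number from compound 3 to compound 4 (0.24 log units; that floor lies within the scatter). This swap of one aromatic ring for another therefore gives no lower number in this test. The true size of the step remains unknown because the result for compound 4 is a limit: the limit of > 100000 nM in this assay, at which 2 of the 4 values shown sit.

Going by these compounds, how far the value of compound 4 lies past that limit remains open. So does the outcome with an amine or a longer chain at this carbon.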